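The source may hold more compounds than are shown below. What is called first, only, known or untested is meant among the compounds shown, and "the series" means these compounds.

Of the compounds shown here, three of one series have been measured in a physicochemical assay for lipophilicity, using the shake flask method; a higher number here means a more lipophilic compound, a lower number a more polar compound. Compound 1 `C=CCO/N=C/c1c(N)ncnc1Oc1ccc(NC(=O)C2(C(=O)Nc3ccc(F)cc3)CC2)cc1F` gives 3.65. Compound 2 `Nc1ncnc(Oc2ccc(NC(=O)C3(C(=O)Nc4ccc(F)cc4)CC3)cc2F)c1/C=N/O` gives 2.62. Compound 3 `CNc1ncnc(Oc2ccc(NC(=O)C3(C(=O)Nc4ccc(F)cc4)CC3)cc2F)c1/C=N/OC` gives 3.52. Compound 2 stands lowest of the three in this assay: its nearest neighbour is compound 3, and compound 1 lies furthest from it.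

The step to compound 4 `Nc1ncnc(Oc2ccc(NC(=O)C3(C(=O)Nc4ccc(F)cc4)CC3)cc2F)c1/C=N/OCCCN1CCCC1` is the change (3-(pyrrolidin-1-yl)propyl in place of hydrogen on an oxygen), on an oxygen whose other neighbour is a double-bonded nitrogen. Among the measured compounds shown here, two measured steps touch the same oxygen. The step of a number 1.03 log units lower from compound 1 to compound 2 (beyond the scatter) runs the other way, replacing allyl with hydrogen, so reversing it shows what putting a carbon chain on this oxygen did. The step of a number 0.90 log units higher from compound 2 to compound 3 (beyond the scatter) also adds a methyl to this oxygen, though together with a second methyl on a nitrogen. Both point to a rise in this assay when the hydrogen is replaced by a carbon chain, and so a rise beyond the scatter is expected for compound 4, with the step of a number 0.68 log units higher from compound 2 to compound 4 (beyond the scatter). Compound 4 is therefore estimated at 3.3, within a range from 2.5 to 4.1.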

Compound 4, partition coefficient: 3.82
Compound 4: the middle estimate sits 0.52 log units below what was measured; measured number inside the range.
By their numbers in this assay, from the lowest: compound 2; then compounds 3, 1 and 4 (each within the scatter of the next).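

In this assay, 3-(pyrrolidin-1-yl)propyl on this oxygen gives a number 1.20 log units higher from compound 2 to compound 4 (beyond the scatter), so a chain that carries a ring with a nitrogen also stands above the free hydroxy form, as the allyl chain of compound 1 does. The new comparison is between the two chains themselves, which show a number 0.17 log units higher from compound 1 to compound 4 (within the scatter). On this oxygen, then, this assay does not separate allyl from 3-(pyrrolidin-1-yl)propyl, even though they differ in size and one contains a ring.

On these data alone, whether a chain ending in a morpholine or a carboxylic acid, or a plain alkyl chain of similar length, would stand level with these two remains open. Nothing available explains why these two different chains give numbers within the scatter of each other.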